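This account rests on a few compounds, and the source may have more. Where it says the series, first, only, none or still open, it means among the compounds named here.

The measured compounds, each with its result in a functional assay on HEK293 cells (Homo sapiens) for cytotoxicity; on this read-out higher numbers stand for lower toxicity in this test and lower numbers for higher toxicity in this test:

Compound 1, `COc1ccc([C@H]2CC(=O)N(Cc3cccc(C#N)c3)C2)cc1OC1CCCC1`. In this assay compound 1 gives > 10000 nM, which is a limit of the assay and not a number.
Compound 2, `COc1ccc([C@H]2CC(=O)N(c3ccccc3)C2)cc1OC1CCCC1`. In this assay compound 2 gives > 10000 nM, again only a limit.
Compound 3, `COc1ccc([C@H]2CC(=O)N(c3cccc(N)c3C)C2)cc1OC1CCCC1`. In this assay compound 3 gives > 10000 nM, again only a limit.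

Compound 2 therefore stands at the same limit as the other two, (the limit of > 10000 nM in this assay, at which 3 of the 3 values shown sit). The three compounds share one core and differ only in the group on the amide-type nitrogen in a ring, yet none of the steps between them can be read: a step that the two limits leave unreadable from compound 1 to compound 2, a step that the two limits leave unreadable from compound 1 to compound 3 and a step that the two limits leave unreadable from compound 2 to compound 3.

Compound 4, `COc1ccc([C@H]2CC(=O)N(c3ccncc3)C2)cc1OC1CCCC1`, has not yet been measured. It differs from compound 2 in the same place: pyridin-4-yl in place of phenyl on an amide-type nitrogen in a ring. Among the measured compounds shown here, the steps that bear on this change are the three swaps on that nitrogen, and all three are unreadable because every value sits at the limit (the limit of > 10000 nM in this assay, at which 3 of the 3 values shown sit). No step beyond the scatter is expected from compound 2 to compound 4, so the step is estimated at a step that the limit leaves unreadable from compound 2 to compound 4. Compound 4 is accordingly expected to give about 20000 nM, in a range from 10000 nM to 60000 nM, most likely reported again only as a limit.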

Compound 4, half-maximal cytotoxic concentration: > 10000 nM
Compound 4: no number, only a limit; the forecaster's own chance of this, stated with the estimate: 85%; the middle value does not contradict the limit.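

In this assay compound 4 gives > 10000 nM, which is a limit and not a number. The steps to compound 4 from compound 1, compound 2 and compound 3 therefore cannot be read: the limit of > 10000 nM in this assay, at which 4 of the 4 values shown sit. The compounds shown leave open where their true values lie and whether the groups on the amide-type nitrogen differ at all in this assay.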